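Cyclohexylethyl to benzyl on the acylguanidine series

The source may report more compounds than this note shows. Statements on the series, on what has been measured and on what is new or still open speak of the compounds shown alone.

The three measured compounds share an aminothiazole core carrying a propyl chain that ends in an acylguanidine, and they differ only in the group on the amide-type nitrogen. Compound 1 `Cc1nc(N)sc1CCCN/C(N)=N/C(=O)N[C@H](C)c1ccccc1` gives 45.7 nM in a functional assay on HEK293T cells for agonist activity at histamine H2 receptor (Homo sapiens), read by beta-arrestin recruitment (a lower number here means that less compound is needed, a higher number that more compound is needed for the effect), compound 2 `CCCNC(=O)/N=C(\N)NCCCc1sc(N)nc1C` gives 170 nM, and compound 3 `Cc1nc(N)sc1CCCN/C(N)=N/C(=O)NCC(C)C1CCCCC1` gives 224 nM, the highest of the three numbers. The change a 3.7-fold higher number from compound 1 to compound 2 (0.57 log units; beyond the scatter) is modest but beyond the scatter, whereas the change a 1.3-fold higher number from compound 2 to compound 3 (0.12 log units; within the scatter) stays within it.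

Compound 4 `Cc1nc(N)sc1CCCN/C(N)=N/C(=O)NCc1ccccc1` arises from compound 3 by phenyl in place of 1-cyclohexylethyl on a saturated chain carbon bound to an amide-type nitrogen. Going by the values given here, no measured step matches this exchange directly. The nearest reference is compound 1, whose 1-phenylethyl group differs from the benzyl group of compound 4 by one methyl. In this assay compound 1 gives 45.7 nM, whereas compound 3 gives 224 nM. On that basis compound 4 is expected to move toward the number of compound 1, a step of about a 2.8-fold lower number from compound 3 to compound 4 (0.45 log units; beyond the scatter). Compound 4 is therefore estimated at 80 nM, within a range from 30 nM to 250 nM.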

Compound 4, half-maximal effective concentration: 100 nM
The estimate for compound 4 lay 1.3-fold (0.10 log units) below the measured number; the range from low to high includes it.
By their numbers in this assay, from the lowest: compound 1; then compounds 4, 2 and 3 (each within the scatter of the next, the first and the last beyond it).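

In this assay, phenyl in place of 1-cyclohexylethyl gives a 2.2-fold lower number from compound 3 to compound 4 (0.35 log units; beyond the scatter), so this exchange on a saturated chain carbon bound to an amide-type nitrogen registers, though only modestly. Phenyl in place of ethyl at the same place gives a 1.7-fold lower number from compound 2 to compound 4 (0.23 log units; within the scatter), so on these numbers the aromatic ring cannot be told apart from the open chain. Hydrogen in place of methyl gives a 2.2-fold higher number from compound 1 to compound 4 (0.34 log units; beyond the scatter), which shows for the first time that a single methyl on the carbon bound to an amide-type nitrogen and an aromatic carbon counts on its own.

The compounds shown leave open how a pyridine ring in place of phenyl, or a phenyl ring carrying a fluorine or a methoxy group, would behave here. They also leave open whether the mirror-image form of the 1-phenylethyl group or a longer chain ending in phenyl would match compound 1. Nothing available speaks to the cause of these steps.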